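Chloro added to an acylsulfonamide series: permeability outlook

The compounds below may be only part of what the source reports. "The series", "measured", "known", "first", "only" and "open" are said of these compounds alone.

Measured compounds:
compound 1 `CC(C)COc1ncc(-c2cn(C)c3cc(C(=O)NS(C)(=O)=O)ccc23)cc1Cl`: < 15 nm/s
compound 2 `CC(C)COc1ccc(-c2cn(C)c3cc(C(=O)NS(=O)(=O)C4CC4)c(F)cc23)cn1`: 120 nm/s
compound 3 `CC(C)COc1ncc(-c2nn(C)c3cc(C(=O)NS(C)(=O)=O)ccc23)cc1Cl`: "not determined" (no result reported)

Among the measured compounds shown here, in an ADME assay on Caco-2 cells (Homo sapiens) for permeability, in the apical to basolateral direction (a lower number here means that the compound crosses the layer more slowly, a higher number that the compound crosses the layer faster), compound 2 gives 120 nm/s, the only single number among the three entries. Compound 1, in this assay, gives < 15 nm/s, which is a limit of the assay and not a number; it is the case described by the limit of < 15 nm/s in this assay, at which 1 of the 3 values shown sits. Compound 3, in this assay, gives "not determined" (no result reported). For the measured compounds named here, no two of the measured compounds differ in a single place, so no measured step is available.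

Compound 4 `CC(C)COc1ncc(-c2cn(C)c3cc(C(=O)NS(=O)(=O)C4CC4)c(F)cc23)cc1Cl` differs from compound 2 by chloro in place of hydrogen on an aromatic carbon. Compound 1 also carries a chloro group and a methylsulfonyl group in place of the cyclopropylsulfonyl group, and lacks the fluoro group of compound 4; its value shows only that it sits at the limit, and compound 2 shows a number well clear of it. On that footing compound 4 is expected to move down from compound 2 by a modest amount, roughly a 1.7-fold lower number from compound 2 to compound 4 (0.23 log units; within the scatter), a step that may stay within the usual scatter of this assay. Compound 4 is thus estimated at 70 nm/s, expected to fall between 20 nm/s and 200 nm/s, with some chance that only a limit is reported.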

Compound 4, apparent permeability: 34 nm/s
The estimate for compound 4 lay 2.1-fold (0.31 log units) above the measured number; the range from low to high includes it.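

Among the compounds shown here, at this position, on an aromatic carbon ortho to an isobutoxy group and two atoms from the ring nitrogen, chloro in place of hydrogen gives the first single-place step in this assay: a 3.5-fold lower number from compound 2 to compound 4 (0.55 log units; beyond the scatter). The change of one hydrogen for chloro is thus enough on its own to give a step beyond the usual scatter, yet compound 4 still returns a measured number, 34 nm/s, with its fluoro and cyclopropylsulfonyl groups in place. Compound 1, which also carries chloro but differs from compound 4 in more than one place, gives only a limit of the assay and not a number, so it adds no step: the limit of < 15 nm/s in this assay, at which 1 of the 4 values shown sits.

Going by these compounds, what remains open is whether this single step holds on the methylsulfonyl compounds or without the fluoro group, since compound 1 gives no number and compound 3 has no result. On these data alone, it is also open whether the step is particular to chloro, as a methyl group, a methoxy group or a nitrile at the same aromatic carbon would show, and whether the isobutoxy group beside which it was read matters to its size.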